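Acetylphenoxy to Benzotriazolyloxy on a Lactone Ester Chain

The source may report more compounds than this note shows. Statements on the series, on what has been measured and on what is new or still open speak of the compounds shown alone.

Measured compounds:
compound 1, `C=C1C(=O)O[C@@H]2CC(C)=C([C@@H](C)CCCOC(C)=O)[C@@H](OC(=O)CN(CC)CC)[C@H]12`, 11600 nM
compound 2, `C=C1C(=O)O[C@@H]2CC(C)=C([C@@H](C)CCCOC(C)=O)[C@@H](OC(=O)CN3CCCCC3)[C@H]12`, 11500 nM
compound 3, `C=C1C(=O)O[C@@H]2CC(C)=C([C@@H](C)CCCOC(C)=O)[C@@H](OC(=O)COc3ccc(C(C)=O)cc3)[C@H]12`, 49600 nM

In a functional assay on SGC-7901 cells (Homo sapiens) for cytotoxicity, read by sulforhodamine B assay, with a stated time of 72 h (a higher number here means a weaker inhibitor, a lower number a stronger inhibitor), compound 3 stands highest of the three numbers; its two neighbours are compound 1 and compound 2, each reached by a 4.3-fold higher number from compound 1 to compound 3 (0.63 log units; beyond the scatter) and a 4.3-fold higher number from compound 2 to compound 3 (0.63 log units; beyond the scatter) read backwards, while compound 1 and compound 2 themselves differ by a 1.0-fold lower number from compound 1 to compound 2 (0.00 log units; within the scatter).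

Compound 4, `C=C1C(=O)O[C@@H]2CC(C)=C([C@@H](C)CCCOC(C)=O)[C@@H](OC(=O)COc3cccc4[nH]nnc34)[C@H]12`, is not yet measured. It differs from compound 3 by a group of 9 heavy atoms (6 carbon, 3 nitrogen; one five-membered aromatic ring with 3 hetero atoms, one six-membered aromatic ring of carbon only) in place of a group of 9 heavy atoms (8 carbon, 1 oxygen; one six-membered aromatic ring of carbon only), on an oxygen on a saturated carbon. Both groups are aromatic ethers of the same size on the same oxygen, so the change is of a different kind from the two measured steps, which swapped an amine for an aryl ether. Those steps, a 4.3-fold higher number from compound 1 to compound 3 (0.63 log units; beyond the scatter) and a 4.3-fold higher number from compound 2 to compound 3 (0.63 log units; beyond the scatter), were modest and alike, and they say nothing direct about exchanging one aryloxy group for another. Going by the values given here, with no measured step bearing on it, the step of a 1.2-fold lower number from compound 3 to compound 4 (0.09 log units; within the scatter) is expected to stay close to the scatter, in either direction. Compound 4 is therefore estimated at 40000 nM, with a range from 15000 nM to 100000 nM.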

Compound 4, half-maximal inhibitory concentration: 21100 nM
Estimate against measurement, compound 4: 1.9-fold (0.28 log units) above; the measured number falls inside the stated range.
By their numbers in this assay, from the lowest: compounds 2, 1 and 4 (each within the scatter of the next); then compound 3.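

In this assay, exchanging one aryloxy group for another on this oxygen does shift the number, with a 2.4-fold lower number from compound 3 to compound 4 (0.37 log units; beyond the scatter) as the first step shown between two aromatic ethers of equal heavy-atom count, so the outcome at this position is not set by the amine-to-aryl-ether swap alone. Until now compound 3 was the only aryl ether, and it stood apart from both amines; with a 1.8-fold higher number from compound 2 to compound 4 (0.26 log units; within the scatter) and with a 1.8-fold higher number from compound 1 to compound 4 (0.26 log units; within the scatter), an aryl ether now lies within the scatter of the piperidin-1-yl and diethylamino compounds, so the aryloxy link on this chain does not by itself separate a compound from them. Nothing measured here accounts for the difference between the 4-acetylphenyl group and the entering group.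

The compounds shown do not separate the contribution of the ring nitrogens and their hydrogen from that of the lost acetyl group, and a plain phenoxy group on the same oxygen-linked chain would bear directly on that question. From the compounds shown here alone, it also remains open whether another amine on this chain carbon, such as morpholine, would give a number clearly apart from those of compound 1 and compound 2.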